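Vinyl dihydrofuran amides: isobutyl for propyl on the amide

This account rests on a few compounds, and the source may have more. Where it says the series, first, only, none or still open, it means among the compounds named here.

Compound 1 `C=CC1=C(C(=O)NCCC)C(c2ccc(F)cc2)OC1` in a functional assay on A549 cells (Homo sapiens) for cytotoxicity, read by MTT assay, with a stated time of 24 h (on this read-out lower numbers stand for stronger inhibition and higher numbers for weaker inhibition), gives > 100000 nM, which is a limit of the assay and not a number.
Compound 2 `C=CC1=C(C(=O)NCCC)C(c2ccc(Cl)c(Cl)c2)OC1` in this assay gives > 100000 nM, again a limit rather than a number.
Compound 3 `C=CC1=C(C(=O)NCC(C)C)C(c2ccc(F)cc2)OC1` in this assay gives > 100000 nM, also only a limit.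

Compound 3 arises from compound 1 by methyl in place of hydrogen on a saturated chain carbon bound to two saturated chain carbons. The size of that step, a step that the two limits leave unreadable from compound 1 to compound 3, cannot be read because the limit of > 100000 nM in this assay, at which 3 of the 3 values shown sit, holds every value shown. How the core of compound 2 differs from the core of compound 1 is not broken down here. Compound 4 `C=CC1=C(C(=O)NCC(C)C)C(c2ccc(Cl)c(Cl)c2)OC1`, not yet measured, arises from compound 2 by methyl in place of hydrogen on a saturated chain carbon bound to two saturated chain carbons, the same change at the same place. Compound 4 is expected to give 150000 nM in this assay, most likely again as a limit. This expected step that the limit leaves unreadable from compound 2 to compound 4 rests on the unreadable step that the two limits leave unreadable from compound 1 to compound 3 and on (the limit of > 100000 nM in this assay, at which 3 of the 3 values shown sit).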

Compound 4, half-maximal inhibitory concentration: > 100000 nM
Compound 4 was reported as a limit; the forecaster's own chance of this, stated with the estimate: 85%; the middle value does not contradict the limit.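

No size can be read for the step from propyl to isobutyl between compound 2 and compound 4, because both values are limits and not numbers: the limit of > 100000 nM in this assay, at which 4 of the 4 values shown sit.

The compounds shown leave open whether propyl and isobutyl differ at all in their effect on these cells.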